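Swapping a methoxyphenyl pattern on the amide cap

A few compounds are considered here, and "the series" means these few. Any claim that something is new, unique, unknown or untested is made for them only; others in the source may bear on it.

Compound 2 `COc1ccc(C(=O)N(CCC(=O)NCc2ccccc2)Cc2ccc(C(=O)NO)cc2)cc1` carries a hydroxamic acid on a shared core. Among the measured compounds shown here, in a functional assay on CHP-134 cells (Homo sapiens) for antiproliferative activity, with a stated time of 72 h (on this read-out lower numbers stand for stronger inhibition and higher numbers for weaker inhibition), compound 2 gives 1900 nM, the higher of the two numbers measured so far. Compound 1 `Cc1ccc(NC(=O)CCN(Cc2ccc(C(=O)NO)cc2)C(=O)c2cc(C)cc(C)c2)cc1` gives 380 nM in this assay, a gap beyond the usual scatter. Compound 3 `COc1cc(OC)cc(C(=O)N(CCC(=O)NCc2ccccc2)Cc2ccc(C(=O)NO)cc2)c1` differs from compound 2 in one place: 3,5-dimethoxyphenyl in place of 4-methoxyphenyl on a carbonyl carbon. For the measured compounds named here, no measured pair isolates this change, so the step from compound 2 to compound 3 is uncertain. The step of a 1.5-fold lower number from compound 2 to compound 3 (0.16 log units; within the scatter) is expected to be small, within or near the scatter. Compound 3 is therefore estimated at 1300 nM, with a range from 450 nM to 3800 nM.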

Compound 3, half-maximal inhibitory concentration: 12300 nM
The estimate for compound 3 lay 9.5-fold (0.98 log units) below the measured number, and the stated range ends below it.
By their numbers in this assay, from the lowest: compound 1; then compound 2; then compound 3.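

In this assay, swapping 4-methoxyphenyl for 3,5-dimethoxyphenyl on the carbonyl carbon gives a 6.5-fold higher number from compound 2 to compound 3 (0.81 log units; beyond the scatter). Among the compounds shown here, this is the first measured pair to isolate a change at this place, and it shows that activity here depends on the methoxy pattern of the ring. No measurement on hand accounts for this step.

On these data alone, what remains open is whether the added methoxy group or the changed substitution pattern matters more, a question a 3-methoxyphenyl group at this place could help settle. As far as these compounds go, how a plain phenyl ring or a 4-chlorophenyl group would fare here also remains unknown.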